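A few compounds are considered here, and "the series" means these few. Any claim that something is new, unique, unknown or untested is made for them only; others in the source may bear on it.

Measured compounds:
compound 1, `Cc1cc(O)c(C2=NN(c3ccc(S(N)(=O)=O)cc3)C(c3ccccc3O)C2)cc1Cl`: in a functional assay on Malme-3M cells (Homo sapiens) for antiproliferative activity, with a stated time of 48 h (on this read-out higher numbers stand for lower toxicity in this test and lower numbers for higher toxicity in this test), compound 1 gives 59200 nM.
compound 2, `Cc1cc(O)c(C2=NN(c3ccc(S(N)(=O)=O)cc3)C(/C=C/c3ccccc3)C2)cc1Cl`: in this assay compound 2 gives 51900 nM.

Compound 2 holds the lowest of the two numbers shown, with compound 1 the nearest, and that gap is within the scatter.

Compound 3 is `COc1ccc(C2CC(c3cc(Cl)c(C)cc3O)=NN2c2ccc(S(N)(=O)=O)cc2)c(OC)c1OC`, not yet measured in this assay. Against compound 2 the change is 2,3,4-trimethoxyphenyl in place of 2-phenylethenyl on a saturated ring carbon.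

Going by the values given here, one measured step bears on this position: a 1.1-fold lower number from compound 1 to compound 2 (0.06 log units; within the scatter), a swap of one group for another on the same saturated ring carbon that left the number essentially where it was. That step is the whole record at this place. A further group of the same kind entering there is therefore expected to move the number little, and no step beyond the scatter is expected in this assay. The step from compound 2 to compound 3 is estimated as a 1.2-fold lower number from compound 2 to compound 3 (0.06 log units; within the scatter). For compound 3 the expected value in this assay is 45000 nM, with a range from 15000 nM to 130000 nM.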

Compound 3, concentration lethal to 50% of the cells: 21400 nM
For compound 3 the middle estimate is 2.1-fold (0.32 log units) above the measured one; the range from low to high includes it.
By their numbers in this assay, from the lowest: compound 3; then compounds 2 and 1 (each within the scatter of the next).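

In this assay, the saturated ring carbon next to the ring nitrogen now shows that it can register a change: a 2.4-fold lower number from compound 2 to compound 3 (0.38 log units; beyond the scatter) and a 2.8-fold lower number from compound 1 to compound 3 (0.44 log units; beyond the scatter) both lie beyond the scatter, though both are modest, whereas the swap between 2-hydroxyphenyl and 2-phenylethenyl gave no readable shift. Compound 3 therefore separates from the other two at the lower-number end, which here means higher toxicity in this test, so the position does not accept every aryl-bearing group alike. The entering 2,3,4-trimethoxyphenyl has 12 heavy atoms and 3 hydrogen-bond acceptors against 8 heavy atoms and 0 acceptors for 2-phenylethenyl, but no measurement in hand explains why this group gives the lower number.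

The compounds shown leave open whether all three methoxy groups are needed, since a single 4-methoxyphenyl or an unsubstituted phenyl at this carbon would separate the ring from its substituents. They also leave open how far the trend extends beyond aryl and styryl-type groups, for example to a dimethylamino-bearing phenyl or a carboxylic acid on the ring, and whether the gap holds in other cell lines.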